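A Methyl Group Added to the Weaker Compound

The source may report more compounds than this note shows. Statements on the series, on what has been measured and on what is new or still open speak of the compounds shown alone.

In a functional assay on HepG2 cells (Homo sapiens) for antiproliferative activity, read by MTT assay, with a stated time of 72 h (a higher number here means a weaker inhibitor, a lower number a stronger inhibitor), compound 1 (`C=C(c1cc(OC)nc(OC)c1)c1ccc(OC)c(O)c1`) gives 77 nM and compound 2 (`C=C(c1ccncc1)c1ccc(OC)c(O)c1`) gives 261 nM as the higher number of the two, which makes compound 2 the weaker inhibitor by a gap beyond the usual scatter. Compound 3 (`C=C(c1ccnc(C)c1)c1ccc(OC)c(O)c1`) differs from compound 2 in one place (methyl in place of hydrogen on an aromatic carbon): methyl in place of hydrogen on an aromatic carbon, next to the ring nitrogen. Compound 1 also carries groups next to the ring nitrogen and gives the lower 77 nM in this assay so a modest drop is expected, near the edge of the scatter. The estimate is a step (a 1.7-fold lower number from compound 2 to compound 3 (0.24 log units; within the scatter)) towards a stronger inhibitor. For compound 3 the expected value is 150 nM (60 nM to 350 nM).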

Compound 3, half-maximal inhibitory concentration: 31 nM
Beside the measured number, compound 3's estimate is 4.8-fold (0.68 log units) above it, outside the stated range (below it).
By their numbers in this assay, from the lowest: compound 3; then compound 1; then compound 2.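

Swapping one hydrogen for a methyl next to the ring nitrogen gives an 8.4-fold lower number from compound 2 to compound 3 (0.93 log units; beyond the scatter) in this assay and moves towards a stronger inhibitor. This position therefore responds strongly to change, and a single added carbon, with no hydrogen-bond donors or acceptors, is enough to produce a step beyond the usual scatter. No measurement shown here accounts for the size of this step. Still open, from the compounds shown here alone, is how an ethyl group or an amine on the same carbon would compare. A second methyl on the ring's other carbon next to the ring nitrogen also remains an open case.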